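A few compounds are considered here, and "the series" means these few. Any claim that something is new, unique, unknown or untested is made for them only; others in the source may bear on it.

Measured compounds in an assay (Rattus norvegicus) for inhibition of Fatty-acid amide hydrolase 1 (Homo sapiens); on this read-out higher numbers stand for weaker inhibition and lower numbers for stronger inhibition:
compound 1 `N#Cc1cccc(-c2cnc(C(=O)CCCCCCc3ccccc3)o2)c1`, 15 nM
compound 2 `COC(=O)c1ccc(-c2cnc(C(=O)CCCCCCc3ccccc3)o2)cc1`, 40 nM

Compound 2 gives the higher of the two numbers recorded in this assay; compound 1 sits lower, and the gap between the two lies beyond the usual scatter. Among the compounds with values here, no step between measured compounds differing in a single place has been recorded, so the effect of a substituent swap on this aromatic ring rests on nothing direct. Compound 3 `NS(=O)(=O)c1ccc(-c2cnc(C(=O)CCCCCCc3ccccc3)o2)cc1` is the next compound; it differs from compound 2 by sulfamoyl in place of methoxycarbonyl on an aromatic carbon. Within the data shown here, with no comparable step available, the expectation for compound 3 is a step from compound 2 of modest size, if any, with a lean toward a somewhat higher number: the expected step is a 1.3-fold higher number from compound 2 to compound 3 (0.10 log units; within the scatter). Compound 3 is therefore estimated at 50 nM in this assay, within a range of 15 nM to 160 nM.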

Compound 3, inhibition constant: 10 nM
Estimate against measurement, compound 3: 5.0-fold (0.70 log units) above, outside the stated range (below it).
By their numbers in this assay, from the lowest: compounds 3 and 1 (each within the scatter of the next); then compound 2.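

In this assay, within the data shown here, sulfamoyl in place of methoxycarbonyl on the aromatic carbon para to a large group gives a 4.0-fold lower number from compound 2 to compound 3 (0.60 log units; beyond the scatter) as the first single-place step. This position therefore responds to the identity of the group even when the size stays level, with 4 heavy atoms leaving and 4 entering, while the entering group carries 1 hydrogen-bond donor and the leaving group has none. Nothing measured here accounts for the step.

Still open, as far as these compounds go, is whether the lower number follows the donor hydrogen of the sulfamoyl, a question that a carboxamide or a dimethylsulfamoyl group on the same carbon would address. Also open, from the compounds shown here alone, is whether the same swap gives a step of similar size with a shorter chain on the shared core.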